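The source may hold more compounds than are shown below. What is called first, only, known or untested is meant among the compounds shown, and "the series" means these compounds.

Compound 1 `Cc1nc(NC(=O)c2ccccc2)c2nn(-c3ccccc3)cc2n1` is the reference point here. Among the compounds with values here, in an assay on CHO cells for displacement of a labelled ligand from adenosine receptor A3 (Homo sapiens), read by scintillation counting, with a stated time of 60 min (a higher number here means a weaker inhibitor, a lower number a stronger inhibitor), compound 1 gives 5.6 nM, the lowest of the three numbers measured so far. Compound 3 `Cc1nc(N(C(=O)c2ccccc2)C(=O)c2ccccc2)c2nn(-c3ccccc3)cc2n1` carries a second benzoyl on the amide-type nitrogen and gives 33 nM. The step of a 5.9-fold higher number from compound 1 to compound 3 (0.77 log units; beyond the scatter) is modest. Within the data shown here, compound 2 `COc1ccc(-n2cc3nc(-c4ccccc4)nc(NC(C)=O)c3n2)cc1` differs from compound 1 in several places at once; in this assay compound 2 gives 98 nM, and its two values with compound 1 show only that compound 2 sits clearly higher.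

Compound 4 `Cc1nc(NC(=O)c2ccco2)c2nn(-c3ccccc3)cc2n1` has not yet been measured. It differs from compound 1 by furan-2-yl in place of phenyl on a carbonyl carbon. Among the measured compounds shown here, none of the measured steps changes the group on the carbonyl carbon; the one step that touches the amide, from compound 1 to compound 3, alters the nitrogen instead, so it bears on this change only loosely. Without a direct precedent, compound 4 is expected to stay close to compound 1, with a step of a 1.3-fold higher number from compound 1 to compound 4 (0.10 log units; within the scatter) that need not reach beyond the scatter. Compound 4 is therefore estimated at 7 nM, within 2.5 nM to 25 nM.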

Compound 4, inhibition constant: 20 nM
For compound 4 the middle estimate is 2.9-fold (0.46 log units) below the measured one; measured number inside the range.
By their numbers in this assay, from the lowest: compound 1; then compounds 4 and 3 (each within the scatter of the next); then compound 2.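

Within the data shown here, the group on the carbonyl carbon, which the earlier compounds left unchanged, does matter in this assay: the step of a 3.6-fold higher number from compound 1 to compound 4 (0.55 log units; beyond the scatter) is the first direct reading of it, modest but beyond the scatter. Phenyl and furan-2-yl are therefore not interchangeable here, and, with the step of a 5.9-fold higher number from compound 1 to compound 3 (0.77 log units; beyond the scatter) made on the nitrogen, both single changes shown at this amide raise the number. Nothing measured here explains the rise.

The two rings differ in both ring size and the ring oxygen, so this single exchange cannot show which of the two differences matters. From the compounds shown here alone, a pyridyl group, a six-membered ring containing nitrogen, or a cyclohexyl group on the same carbonyl carbon would be needed to separate ring size from ring atoms, and its effect remains open.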